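Dihydrostilbene series: removing the methoxy from the second ring

A few compounds are considered here, and "the series" means these few. Any claim that something is new, unique, unknown or untested is made for them only; others in the source may bear on it.

Measured so far:
compound 1 `COc1cc(CCc2ccc(Br)cc2)cc(OC)c1O` — > 25000 nM
compound 2 `COc1cc(CCc2ccccn2)cc(OC)c1O` — > 25000 nM
compound 3 `COc1ccccc1CCc1cc(OC)c(O)c(OC)c1` — 1740 nM

For the measured compounds named here, in a functional assay on A549 cells (Homo sapiens) for antiproliferative activity, read by MTT assay, with a stated time of 72 h (a higher number here means a weaker inhibitor, a lower number a stronger inhibitor), compound 3 gives 1740 nM, the only number so far obtained in the set. For compound 1 the result is a limit of the assay, > 25000 nM. For compound 2 the result is likewise a limit, > 25000 nM. Two of three values therefore sit at the limit of > 25000 nM in this assay, at which 2 of the 3 values shown sit, and compound 3 alone gives a measurable reading.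

Compound 4 `COc1cc(CCc2ccccc2)cc(OC)c1O` has not yet been tested. It differs from compound 3 by hydrogen in place of methoxy on an aromatic carbon. Going by the values given here, no pair of measured compounds differs in only one place, so no measured step is available for comparison. The expectation is that compound 4 is weaker in this assay than compound 3, a step of a 3.4-fold higher number from compound 3 to compound 4 (0.54 log units; beyond the scatter) beyond the usual scatter, with a real chance that only a limit is returned. The estimate for compound 4 is 6000 nM, in the range 1500 nM to 25000 nM.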

Compound 4, half-maximal inhibitory concentration: 10900 nM
For compound 4 the middle estimate is 1.8-fold (0.26 log units) below the measured one; the measured number falls inside the stated range.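

In this assay, a 6.3-fold higher number from compound 3 to compound 4 (0.80 log units; beyond the scatter) gives the first measured size for this change: the methoxy on the aromatic carbon ortho to a large group counts for real activity, yet compound 4 still gives a measurable reading without it. The second ring also matters when it carries neither group, with an at least 2.2-fold lower number from compound 2 to compound 4 (0.36 log units; beyond the scatter) for phenyl in place of pyridin-2-yl and an at least 2.2-fold lower number from compound 1 to compound 4 (0.36 log units; beyond the scatter) for hydrogen in place of bromo. Compound 1 and compound 2 stand at a limit of the assay and not at a number, so these two steps are bounds only: the limit of > 25000 nM in this assay, at which 2 of the 4 values shown sit.

As far as these compounds go, it remains open whether a hydroxyl, an ethoxy or an amine on the same aromatic carbon would match methoxy. From the compounds shown here alone, it is also open whether methoxy on another carbon of that ring would do the same.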